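The source may report more compounds than this note shows. Statements on the series, on what has been measured and on what is new or still open speak of the compounds shown alone.

Two compounds of the series carry numbers in an in vitro ADME assay on microsomes from liver (Homo sapiens) for metabolic stability, with a stated time of 15 min; a higher number here means faster removal of the compound, a lower number slower removal. Compound 1 `CCc1nn2c(-c3c(COC)cc(OC)cc3OC)cccc2c1N(CC1CCOCC1)CC1CC1` gives 530 mL.min-1.g-1. Compound 2 `CCc1nn2c(-c3c(C)cc(C)cc3OC)cccc2c1N(CC1CC1)CC1CCCO1` gives 1230 mL.min-1.g-1, the higher of the two numbers, and its gap to compound 1 lies beyond the usual scatter of the measurement. Compound 3 `CCc1nn2c(-c3c(C)cc(C)cc3OC)cccc2c1N(CCCF)CC1CC1` has not yet been run in this assay. It differs from compound 2 in one place: 2-fluoroethyl in place of oxolan-2-yl on a saturated chain carbon bound to a nitrogen on an aromatic ring. Going by the values given here, no pair of measured compounds shows this change, so nothing measured here tells the size of the step; the expectation rests on the number for compound 2 and on the change itself. In this assay the expected step is small, a 1.2-fold lower number from compound 2 to compound 3 (0.09 log units; within the scatter), within the usual scatter, and its direction is uncertain. Compound 3 is estimated to give 1000 mL.min-1.g-1 in this assay, with a range from 500 mL.min-1.g-1 to 2000 mL.min-1.g-1.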

Compound 3, intrinsic clearance in microsomes: 1410 mL.min-1.g-1
Estimate against measurement, compound 3: 1.4-fold (0.15 log units) below; low and high end bracket the measured number.
By their numbers in this assay, from the lowest: compound 1; then compounds 2 and 3 (each within the scatter of the next).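

In this assay, going by these compounds alone, the first step that can be read at this position, a 1.1-fold higher number from compound 2 to compound 3 (0.06 log units; within the scatter), lies within the scatter. On a saturated chain carbon bound to a nitrogen on an aromatic ring, the five-membered non-aromatic ring with its hydrogen-bond acceptor can therefore give way to the open 2-fluoroethyl chain with no separable difference in this read-out, at least in this one pair. Nothing available bears on why the two numbers fall so close together.

On these data alone, it remains open whether another group in this place, such as an amine, a carboxylic acid or a longer chain, would separate from these two. Compound 1 differs from both in more than one place, so the contribution of each of its differences cannot be read from these compounds.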